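Changing the ring-nitrogen substituent of compound 1

The compounds below may be only part of what the source reports. "The series", "measured", "known", "first", "only" and "open" are said of these compounds alone.

Measured compounds:
Compound 1 `NC(=O)c1c(NC(=O)c2ccccc2Cl)sc2c1CCN(Cc1ccc(Cl)cc1)C2`: > 50000 nM
Compound 2 `NC(=O)c1c(NC(=O)c2ccc(C(F)(F)F)cc2)sc2c1CCN(Cc1ccc(Cl)cc1)C2`: > 50000 nM
Compound 3 `NC(=O)c1c(NC(=O)c2ccccc2F)sc2c1CCN(Cc1ccc(Cl)cc1Cl)C2`: 27500 nM

In a functional assay on HeLa cells (Homo sapiens) for antiproliferative activity, with a stated time of 24 h (on this read-out higher numbers stand for weaker inhibition and lower numbers for stronger inhibition), compound 1 gives > 50000 nM, and this is a limit of the assay rather than a number. Compound 2 also gives only a limit, > 50000 nM. Compound 3 gives a measured number, 27500 nM. Among the measured compounds shown here, the single step between measured compounds that differ in one place is a step that the two limits leave unreadable from compound 1 to compound 2, and with both ends at the limit its size cannot be read. Compound 1 therefore stands at the limit of > 50000 nM in this assay, at which 2 of the 3 values shown sit, without a number of its own.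

Compound 4 `NC(=O)c1c(NC(=O)c2ccccc2Cl)sc2c1CCN(C(=S)Nc1ccccc1Br)C2` differs from compound 1 by a group of 10 heavy atoms (7 carbon, 1 nitrogen, 1 sulfur, 1 bromine; one six-membered aromatic ring of carbon only) in place of a group of 8 heavy atoms (7 carbon, 1 chlorine; one six-membered aromatic ring of carbon only), on an amine nitrogen in a ring. For the measured compounds named here, none of the measured steps bears on this change: the one measured step alters the group on the carbonyl carbon, not the group on the ring nitrogen, and its size is unreadable in any case. The data give no basis for expecting a step beyond the scatter in either direction. Compound 4 is expected to stay near the limit where compound 1 sits, and is estimated at 45000 nM, with a range from 12000 nM to 150000 nM. The expected step is accordingly an at least 1.1-fold lower number from compound 1 to compound 4 (0.04 log units; that floor lies within the scatter).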

Compound 4, half-maximal inhibitory concentration: 24600 nM
Estimate against measurement, compound 4: 1.8-fold (0.26 log units) above; low and high end bracket the measured number.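

In this assay, placing the new group on the amine nitrogen in a ring, with its double bond outside aromatic rings, its hydrogen-bond donor and its hydrogen-bond acceptor, in place of 4-chlorobenzyl gives an at least 2.0-fold lower number from compound 1 to compound 4 (0.30 log units; that floor lies within the scatter). Among the compounds shown here, this is the first step from compound 1 that can be read at all, and it shows that the ring nitrogen can carry a group other than a substituted benzyl while compound 4 still gives a measured number. The step is only a floor, and that floor does not go beyond the scatter, so its true size stays unknown because compound 1 has no number of its own: the limit of > 50000 nM in this assay, at which 2 of the 4 values shown sit.

The compounds shown leave open which part of the new group matters, since its sulfur, nitrogen and bromine all enter together in this single change. They also leave open how the same position would read with a plain phenyl in place of the bromine-bearing ring, with an oxygen in place of the sulfur, or with a simple amine or a longer chain on the ring nitrogen.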